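This account rests on a few compounds, and the source may have more. Where it says the series, first, only, none or still open, it means among the compounds named here.

Measured so far:
compound 1, `CSC(=O)N1CCC(Oc2ncnc3c2CCN3c2ccc(S(C)(=O)=O)cc2F)CC1`: 251 nM
compound 2, `CCSC(=O)N1CCC(Oc2ncnc3c2CCN3c2ccc(S(C)(=O)=O)cc2F)CC1`: 31.6 nM
compound 3, `CCS(=O)(=O)N1CCC(Oc2ncnc3c2CCN3c2ccc(S(C)(=O)=O)cc2F)CC1`: 1580 nM

All three values come from a functional assay on CHO-K1 cells for agonist activity at Glucose-dependent insulinotropic receptor (Homo sapiens), read by a luciferase reporter, with a stated time of 5 h; on this read-out higher numbers stand for an effect only at larger amounts of compound and lower numbers for an effect already at smaller amounts. Compound 4, `CC(C)S(=O)(=O)N1CCC(Oc2ncnc3c2CCN3c2ccc(S(C)(=O)=O)cc2F)CC1`, has not been measured yet. The change from compound 1 to compound 2 is methyl in place of hydrogen on a saturated chain carbon bound to a sulfur; in this assay it gave a 7.9-fold lower number from compound 1 to compound 2 (0.90 log units; beyond the scatter). Compound 3 carries a different core: ethylsulfonyl in place of (methylsulfanyl)carbonyl on an amine nitrogen in a ring, which went with a 6.3-fold higher number from compound 1 to compound 3 (0.80 log units; beyond the scatter). The step from compound 3 to compound 4 is methyl in place of hydrogen on a saturated chain carbon bound to a saturated chain carbon and a sulfonyl sulfur. It is the same kind of change as from compound 1 to compound 2, but not the same one: there the added methyl sits on a saturated chain carbon bound to a sulfur, here on a saturated chain carbon bound to a saturated chain carbon and a sulfonyl sulfur. Resting on a 7.9-fold lower number from compound 1 to compound 2 (0.90 log units; beyond the scatter), which was modest and came on a different core, compound 4 is expected to make a smaller step, a 2.0-fold lower number from compound 3 to compound 4 (0.30 log units; within the scatter). Compound 4 is estimated at 800 nM, likely between 250 nM and 2500 nM.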

Compound 4, half-maximal effective concentration: 1260 nM
For compound 4 the middle estimate is 1.6-fold (0.20 log units) below the measured one, and the stated range covers the measured number.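

The same small change does not carry over at the same size from one core to the other: the same change on two cores in this assay, a 7.9-fold lower number (0.90 log units; beyond the scatter) from compound 1 to compound 2 and a 1.3-fold lower number (0.10 log units; within the scatter) from compound 3 to compound 4, 6.3-fold (0.80 log units) apart, beyond the scatter of two such steps. On the sulfonyl side the step is a 1.3-fold lower number from compound 3 to compound 4 (0.10 log units; within the scatter), so isopropylsulfonyl and ethylsulfonyl cannot be told apart here, while replacing the carbonyl groups on the ring nitrogen still matters, with a 40-fold higher number from compound 2 to compound 4 (1.60 log units; beyond the scatter) and a 5.0-fold higher number from compound 1 to compound 4 (0.70 log units; beyond the scatter). With one pair on each core, this shows that the size of the methyl step depends on its setting, but not why, nor what it would be on any other core.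

Still open, from the compounds shown here alone, is whether a longer chain, such as propyl, would keep improving the (ethylsulfanyl)carbonyl compounds. The same question stands for a branched (isopropylsulfanyl)carbonyl group.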